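The source may hold more compounds than are shown below. What is called first, only, known or untested is meant among the compounds shown, and "the series" means these compounds.

Of the compounds shown here, two have been measured in an assay on HEK293 cells for displacement of a labelled ligand from prostaglandin D2 receptor 2 (Homo sapiens) (a lower number here means a stronger inhibitor, a higher number a weaker inhibitor), so far. Compound 1 `O=C(O)Cn1c(SCCCc2ccccc2)nc2ccccc21` gives 475 nM, and compound 2 `O=C(O)Cn1c(SCCc2ccccc2)nc2ccccc21` gives 881 nM. Among the measured compounds shown here, the one step between them, a 1.9-fold higher number from compound 1 to compound 2 (0.27 log units; within the scatter), puts phenyl in place of benzyl on a saturated chain carbon two bonds along the chain from a sulfur. Compound 2 therefore stands at the upper end of the two numbers, but its distance from compound 1 lies inside the usual spread of repeated measurements, so the two cannot be ranked.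

Compound 3 `O=C(O)Cn1c(SCc2cccc(Cl)c2)nc2ccccc21` has not yet been measured. It differs from compound 2 by 3-chlorophenyl in place of benzyl on a saturated chain carbon bound to a sulfur. That earlier step, a 1.9-fold higher number from compound 1 to compound 2 (0.27 log units; within the scatter), also exchanged a benzyl for a ring attached directly to the chain. For the measured compounds named here, it is the only measured step that bears on this change. Going by the values given here, no measured compound carries a chlorine on the ring, so that part of the change has no precedent here. The expected step is accordingly small, a 1.4-fold higher number from compound 2 to compound 3 (0.13 log units; within the scatter), leaning slightly toward a higher number. Compound 3 is expected to give about 1200 nM in this assay, within the range 400 nM to 3500 nM.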

Compound 3, half-maximal inhibitory concentration: 186 nM
Estimate against measurement, compound 3: 6.5-fold (0.81 log units) above, and the stated range ends above it.
By their numbers in this assay, from the lowest: compound 3; then compounds 1 and 2 (each within the scatter of the next).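

In this assay, among the compounds shown here, putting 3-chlorophenyl in place of benzyl on a saturated chain carbon bound to a sulfur gives a 4.7-fold lower number from compound 2 to compound 3 (0.68 log units; beyond the scatter), the first step that lies beyond the scatter, so the group at this place can shift the number by a clear margin. The earlier step, a 1.9-fold higher number from compound 1 to compound 2 (0.27 log units; within the scatter), stayed within the scatter and involved no chlorine, so it gave no sign of this sensitivity, and compound 3 now has the lowest number of the three. The data at hand offer no measurement that explains the drop.

The new step removes a chain carbon and adds a chlorine in a single change, so the compounds shown cannot divide the effect between the two, and a plain phenyl at the same place would be needed to separate them. Also open, going by these compounds, is whether the chlorine itself matters or whether another group on the ring, such as a fluorine, a methyl or a methoxy, would give a similar number.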